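Fluorine-to-Chlorine Swap on a Diaryl Ether Oxime Series

The compounds below may be only part of what the source reports. "The series", "measured", "known", "first", "only" and "open" are said of these compounds alone.

Three compounds were tested in a functional assay on MCF7 cells (Homo sapiens) for antiproliferative activity, read by MTT assay, with a stated time of 48 h; a lower number here means a stronger inhibitor, a higher number a weaker inhibitor. Compound 1 `O=[N+]([O-])c1cc(C(F)(F)F)cc([N+](=O)[O-])c1Oc1ccc(Br)cc1/C=N\OCc1ccccc1F` gives 1120 nM. Compound 2 `O=[N+]([O-])c1cc(C(F)(F)F)cc([N+](=O)[O-])c1Oc1ccc(Br)cc1/C=N/OCc1ccccc1Cl` gives 2840 nM in this assay. Compound 3 `O=[N+]([O-])c1cc(C(F)(F)F)cc([N+](=O)[O-])c1Oc1c(Cl)cc(Cl)cc1/C=N\OCc1ccccc1F` gives 800 nM in this assay. From compound 1 to compound 2 the change is a group of 11 heavy atoms (8 carbon, 1 nitrogen, 1 oxygen, 1 chlorine; one six-membered aromatic ring of carbon only) in place of a group of 11 heavy atoms (8 carbon, 1 nitrogen, 1 oxygen, 1 fluorine; one six-membered aromatic ring of carbon only), on an aromatic carbon, and the step is a 2.5-fold higher number from compound 1 to compound 2 (0.40 log units; beyond the scatter). Compound 4 `O=[N+]([O-])c1cc(C(F)(F)F)cc([N+](=O)[O-])c1Oc1c(Cl)cc(Cl)cc1/C=N/OCc1ccccc1Cl` has not been measured. It differs from compound 3 by a group of 11 heavy atoms (8 carbon, 1 nitrogen, 1 oxygen, 1 chlorine; one six-membered aromatic ring of carbon only) in place of a group of 11 heavy atoms (8 carbon, 1 nitrogen, 1 oxygen, 1 fluorine; one six-membered aromatic ring of carbon only), on an aromatic carbon, the same kind of change as from compound 1 to compound 2, though the surroundings differ: in compound 1 the place is meta to a bromo group, in compound 3 meta to two chloro groups. The difference between the cores of compound 1 and compound 3 is not broken down here. Because the earlier step was a 2.5-fold higher number from compound 1 to compound 2 (0.40 log units; beyond the scatter), a similar weakening is expected for compound 4. The expected step is a 2.5-fold higher number from compound 3 to compound 4 (0.40 log units; beyond the scatter). Compound 4 is estimated at 2000 nM, between 900 nM and 4500 nM.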

Compound 4, half-maximal inhibitory concentration: 1960 nM
Compound 4: middle estimate off by 1.0-fold (0.01 log units), on the high side, within the range that was stated.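

In this assay the same group exchange that weakened the core of compound 1 also weakened the core of compound 3, with a 2.5-fold higher number from compound 3 to compound 4 (0.39 log units; beyond the scatter) in the new pair. On these two cores the step carried over with no discernible change in size: the same change on two cores in this assay, a 2.5-fold higher number (0.40 log units; beyond the scatter) from compound 1 to compound 2 and a 2.5-fold higher number (0.39 log units; beyond the scatter) from compound 3 to compound 4, 1.0-fold (0.01 log units) apart, within the scatter of two such steps. This rests on two pairs only and does not show that the step would hold on any other core; nor does it isolate the halogen, since the oxime double bond is also drawn with opposite geometry within each pair.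

The compounds shown carry only fluorine or chlorine on the benzyl ring of the exchanged group. From the compounds shown here alone, what an amine, a methoxy group or a carboxylic acid in that place would do remains open.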